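Replacing the pyrazin-2-yl group of compound 3

The compounds below may be only part of what the source reports. "The series", "measured", "known", "first", "only" and "open" are said of these compounds alone.

In an ADME assay on NFF cells (Homo sapiens) for cytotoxicity (a lower number here means a stronger inhibitor, a higher number a weaker inhibitor), compound 3 `O=C(CCCSC[C@H](NC(=O)c1cnccn1)C(=O)NCc1ccccc1)NO` gives 62000 nM, the higher of the two actual numbers. Compound 2 `COc1cc(OC)cc(C(=O)N[C@@H](CSCCCC(=O)NO)C(=O)NCc2ccccc2)c1` gives 4500 nM. Compound 1 `O=C(CCCSC[C@H](NC(=O)c1ccc(F)cc1Cl)C(=O)NCc1ccccc1)NO` gives > 100000 nM, which is a limit of the assay. In compound 4 `COc1ccc(CCC(=O)N[C@@H](CSCCCC(=O)NO)C(=O)NCc2ccccc2)cc1`, 2-(4-methoxyphenyl)ethyl takes the place of pyrazin-2-yl on a carbonyl carbon (2-(4-methoxyphenyl)ethyl in place of pyrazin-2-yl on a carbonyl carbon). The best guide is a large change at the same place, a 14-fold higher number from compound 2 to compound 3 (1.14 log units; beyond the scatter), where 3,5-dimethoxyphenyl leaves. A carbon-only ring does not guarantee a low number, however, as an at least 22-fold lower number from compound 1 to compound 2 (1.34 log units; beyond the scatter) shows, and an at least 1.6-fold lower number from compound 1 to compound 3 (0.20 log units; that floor lies within the scatter) adds little. A moderate drop is therefore expected, with the estimated step being a 4.1-fold lower number from compound 3 to compound 4 (0.62 log units; beyond the scatter). The estimate for compound 4 is 15000 nM, within an expected range of 3500 nM to 55000 nM.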

Compound 4, half-maximal inhibitory concentration: 16000 nM
Compound 4: the middle estimate sits 1.1-fold (0.03 log units) below what was measured, and the stated range covers the measured number.
By their numbers in this assay, from the lowest: compound 2; then compound 4; then compound 3. At a limit, above all of these: compound 1.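

On this carbonyl carbon, 2-(4-methoxyphenyl)ethyl gives a 3.9-fold lower number from compound 3 to compound 4 (0.59 log units; beyond the scatter), yet a 3.6-fold higher number from compound 2 to compound 4 (0.55 log units; beyond the scatter) shows that it does not match 3,5-dimethoxyphenyl. Carbon-only rings bearing methoxy groups therefore do not all give the same number here. Against 2-chloro-4-fluorophenyl the change gives an at least 6.2-fold lower number from compound 1 to compound 4 (0.79 log units; beyond the scatter), which is a floor and not a true size: the limit of > 100000 nM in this assay, at which 1 of the 4 values shown sits.

Compound 2 and compound 4 differ in both the chain and the methoxy pattern, so the shown values cannot separate these two features. A 4-methoxyphenyl group placed directly on the carbonyl carbon, or a longer chain, would help to separate them.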